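Chloro to Trifluoromethyl at Two Ring Positions

The source may hold more compounds than are shown below. What is called first, only, known or untested is meant among the compounds shown, and "the series" means these compounds.

Measured compounds:
compound 1, `CCNC(=O)c1ccc(-c2cc3nnn(C4CCN(c5ncc(CC)cn5)CC4)c3cn2)c(Cl)c1`, 13 nM
compound 2, `CCNC(=O)c1ccc(-c2cc3nnn(C4CCN(c5ncc(CC)cn5)CC4)c3cn2)c(C(F)(F)F)c1`, 60 nM
compound 3, `CCNC(=O)c1ccc(-c2cc3nnn(C4CCN(c5ncc(CC)cn5)CC4)c3cn2)cc1Cl`, 18 nM

In a functional assay on HEK293 cells for agonist activity at Glucose-dependent insulinotropic receptor (Homo sapiens), read by HTRF and cAMP accumulation, with a stated time of 30 min (on this read-out higher numbers stand for an effect only at larger amounts of compound and lower numbers for an effect already at smaller amounts), compound 1 gives 13 nM, and compound 2 gives 60 nM. The change between them is trifluoromethyl in place of chloro on an aromatic carbon, a step of a 4.6-fold higher number from compound 1 to compound 2 (0.66 log units; beyond the scatter). Compound 3 gives 18 nM in this assay; how its core differs from that of compound 1 is not broken down here. Compound 4, `CCNC(=O)c1ccc(-c2cc3nnn(C4CCN(c5ncc(CC)cn5)CC4)c3cn2)cc1C(F)(F)F`, is not yet measured. It differs from compound 3 by trifluoromethyl in place of chloro on an aromatic carbon, the same kind of change as from compound 1 to compound 2, but at a place that is ortho to an ethylcarbamoyl group and meta to a large group rather than ortho to a large group and meta to an ethylcarbamoyl group. Resting on the step of compound 1 to compound 2, a 4.6-fold higher number from compound 1 to compound 2 (0.66 log units; beyond the scatter), a step of similar size, a 3.9-fold higher number from compound 3 to compound 4 (0.59 log units; beyond the scatter), is expected. Compound 4 is therefore estimated at 70 nM in this assay, between 25 nM and 200 nM.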

Compound 4, half-maximal effective concentration in the Glucose-dependent insulinotropic receptor assay: 39 nM
Estimate against measurement, compound 4: 1.8-fold (0.25 log units) above; low and high end bracket the measured number.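

In the Glucose-dependent insulinotropic receptor assay compound 4 gives 39 nM, and trifluoromethyl in place of chloro again gives a higher number on the second core, with a 2.2-fold higher number from compound 3 to compound 4 (0.34 log units; beyond the scatter). The step points the same way as the earlier one, and the two do not differ in size beyond the scatter: the same change on two cores in the Glucose-dependent insulinotropic receptor assay, a 4.6-fold higher number (0.66 log units; beyond the scatter) from compound 1 to compound 2 and a 2.2-fold higher number (0.34 log units; beyond the scatter) from compound 3 to compound 4, 2.1-fold (0.33 log units) apart, within the scatter of two such steps. This shows the change carrying over between these two cores only, and it does not show that the smaller second step is a real difference or that the change would carry to any other core.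

As far as these compounds go, whether a nitrile or a methoxy group in place of chloro would follow the same course stays open. In a physicochemical assay for solubility, read by HPLC, in phosphate buffer, measured as thermodynamic solubility, with a stated time of 24 h, at pH 6.8 (on this read-out lower numbers stand for lower solubility and higher numbers for higher solubility), compound 3 gives < 160 nM, a limit of the assay and not a number. In the physicochemical assay compound 4 gives 510 nM. From the compounds shown here alone, the size of any change on that read-out stays open.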